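Amino in place of ethynyl on compound 1

The compounds below may be only part of what the source reports. "The series", "measured", "known", "first", "only" and "open" are said of these compounds alone.

Compound 1 `C#Cc1cccc(C#Cc2ccc(CCC(=O)O)cc2)c1` holds the second highest of the three numbers in an in vitro functional assay on 1321-N1 cells for agonist activity at Free fatty acid receptor 1 (Homo sapiens), read by fluorescence (a lower number here means that less compound is needed, a higher number that more compound is needed for the effect), where compound 1 gives 155 nM. Compound 2 `Cc1ccc(C#Cc2ccc(CCC(=O)O)cc2)cc1` gives 107 nM, within the scatter of compound 1. Compound 3 `Cc1ccccc1C#Cc1ccc(OCC(=O)O)cc1` gives 3720 nM, a higher number than compound 1 and beyond the scatter; the two values show only that gap. Among the measured compounds shown here, no step between measured compounds differing in one place is available. Compound 4 `Nc1cccc(C#Cc2ccc(CCC(=O)O)cc2)c1` differs from compound 1 by amino in place of ethynyl on an aromatic carbon, meta to a large group. A small step toward a higher number, near the edge of the scatter, is expected from compound 1 to compound 4, estimated at a 2.1-fold higher number from compound 1 to compound 4 (0.31 log units; beyond the scatter). Compound 4 is expected at 320 nM, with a range from 90 nM to 1200 nM.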

Compound 4, half-maximal effective concentration: 1100 nM
For compound 4 the middle estimate is 3.4-fold (0.54 log units) below the measured one; low and high end bracket the measured number.
By their numbers in this assay, from the lowest: compounds 2 and 1 (each within the scatter of the next); then compound 4; then compound 3.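

Amino in place of ethynyl on an aromatic carbon, meta to a large group, gives a 7.1-fold higher number from compound 1 to compound 4 (0.85 log units; beyond the scatter) in this assay, the first step in the series that changes a single place. The number at this position therefore depends on the group it carries: the exchange moves it beyond the scatter. Nothing available bears on the reason for this rise.

From the compounds shown here alone, whether a methoxy group, a chlorine or an acetamide at this position stays closer to compound 1 remains open. Also open, going by these compounds, is whether the same exchange gives a similar step at other positions on this ring.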